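The compounds below may be only part of what the source reports. "The series", "measured", "known", "first", "only" and "open" are said of these compounds alone.

Of the compounds shown here, two of a shared series have been measured in a functional assay on CHO-K1 cells for antagonist activity at transient receptor potential cation channel subfamily V member 1 (Homo sapiens), read by FLIPR; a higher number here means a weaker inhibitor, a lower number a stronger inhibitor. Compound 1 `Cc1ccc(Cl)cc1Nc1nc(C(F)(F)F)ccc1CNC(=O)C(C)c1ccc(NS(C)(=O)=O)c(F)c1` gives 14 nM there, and compound 2 `CC(C(=O)NCc1ccc(C(F)(F)F)nc1N1CCC(Cc2ccc(F)c(F)c2)CC1)c1ccc(NS(C)(=O)=O)c(F)c1` gives 0.2 nM. Compound 2 stands at the lowest of the two numbers; its nearest neighbour is compound 1, whose number is higher by a gap that lies beyond the scatter of repeated measurements.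

Compound 3 `CC(C(=O)NCc1ccc(C(F)(F)F)nc1N1CCC(C(F)(F)F)CC1)c1ccc(NS(C)(=O)=O)c(F)c1` has not yet been measured in this assay. It differs from compound 2 in one place: trifluoromethyl in place of 3,4-difluorobenzyl on a saturated ring carbon. The change removes the aromatic ring and most of the heavy atoms of the leaving group while keeping the rest of the shared core untouched. Among the compounds with values here, no measured pair in this set isolates such a change, so the direction can only be expected, not read off.

The expectation is that compound 3 gives a higher number than compound 2, with a step of a 15-fold higher number from compound 2 to compound 3 (1.18 log units; beyond the scatter) that goes beyond the scatter, and compound 3 is estimated at 3 nM, within a range from 0.5 nM to 20 nM.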

Compound 3, inhibition constant: 0.6 nM
Beside the measured number, compound 3's estimate is 5.0-fold (0.70 log units) above it; the range from low to high includes it.
By their numbers in this assay, from the lowest: compound 2; then compound 3; then compound 1.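

In this assay, the saturated ring carbon three ring bonds from the ring nitrogen keeps a low number without an aromatic ring: trifluoromethyl in place of 3,4-difluorobenzyl gives only a modest step (a 3.0-fold higher number from compound 2 to compound 3 (0.48 log units; beyond the scatter)), although it lies beyond the scatter. At the aromatic carbon of the shared core, 4-(trifluoromethyl)piperidin-1-yl in place of (5-chloro-2-methylphenyl)amino gives a large step (a 23-fold lower number from compound 1 to compound 3 (1.37 log units; beyond the scatter)), so the much smaller group on the piperidine ring retains most of the advantage over compound 1. Nothing available explains either step.

The compounds shown leave open how an unsubstituted benzyl, a methyl or a carboxylic acid on that ring carbon would read in this assay. They therefore cannot separate the part played by the benzyl ring from that of its two fluorines.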